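Amide nitrogen substituent: phenyl to fluorophenylethyl

The compounds below may be only part of what the source reports. "The series", "measured", "known", "first", "only" and "open" are said of these compounds alone.

Compound 1 `COc1cccc(CNC(=O)c2nc(Br)c3cccnc3c2N[C@H]2CC[C@H](N)CC2)c1` gives 6000 nM in a functional assay on HCT-116 cells (Homo sapiens) for cytotoxicity, read by MTT assay, with a stated time of 72 h; a higher number here means a weaker inhibitor, a lower number a stronger inhibitor.
Compound 2 `N[C@H]1CC[C@H](Nc2c(C(=O)NCc3ccc(Cl)cc3Cl)nc(Br)c3cccnc23)CC1` gives 6000 nM in this assay.
Compound 3 `N[C@H]1CC[C@H](Nc2c(C(=O)Nc3ccccc3)nc(Br)c3cccnc23)CC1` gives 2000 nM in this assay.

Compound 3 stands lowest of the three numbers. Both other compounds sit the same distance away: a 3.0-fold lower number from compound 1 to compound 3 (0.48 log units; beyond the scatter), and a 3.0-fold lower number from compound 2 to compound 3 (0.48 log units; beyond the scatter), while no change at the digits printed from compound 1 to compound 2 (within the scatter).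

Compound 4 `C[C@H](NC(=O)c1nc(Br)c2cccnc2c1N[C@H]1CC[C@H](N)CC1)c1ccc(F)cc1` differs from compound 3 in one place: 1-(4-fluorophenyl)ethyl in place of phenyl on an amide-type nitrogen. The two measured steps that bear on this are those from compounds 1 and 2 to compound 3, each a move from a group with a saturated chain carbon bound to an amide-type nitrogen to a plain phenyl, and each lowered the number by a modest but clear amount. Compound 4 moves back to a group of that first kind, so the expectation is a modest rise in this assay, roughly reversing those steps. Going by the values given here, the measured compounds give no step for a methyl on that chain carbon or for fluorine on the ring, so the estimate is kept wide. Compound 4 is expected to give about 5000 nM, within 2000 nM to 12000 nM, which means an estimated 2.5-fold higher number from compound 3 to compound 4 (0.40 log units; beyond the scatter).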

Compound 4, half-maximal inhibitory concentration: > 10000 nM
Compound 4 gave a limit, no number; the forecaster's own chance of this, stated with the estimate: 5%; middle value at least 2.0-fold (0.30 log units) away from the limit.
By their numbers in this assay, from the lowest: compound 3; then compounds 1 and 2 (each within the scatter of the next). At a limit, above all of these: compound 4.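

In this assay compound 4 gives a limit, not a number: the limit of > 10000 nM in this assay, at which 1 of the 4 values shown sits. Against phenyl on the amide-type nitrogen, 1-(4-fluorophenyl)ethyl gives an at least 5.0-fold higher number from compound 3 to compound 4 (0.69 log units; beyond the scatter), which extends the earlier finding at this position: compound 3, with its plain phenyl, still has the lowest number of the four. Against the two benzyl groups the limit says less, with an at least 1.6-fold higher number from compound 2 to compound 4 (0.22 log units; that floor lies within the scatter) and an at least 1.6-fold higher number from compound 1 to compound 4 (0.22 log units; that floor lies within the scatter), so compound 4 cannot be ranked against either compound.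

The effects of the methyl on the chain carbon and the fluorine on the ring remain unseparated, as each enters only together with the other in compound 4. Also open, as far as these compounds go, is how the number would respond to an amine or a carboxylic acid on the phenyl ring of compound 3.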